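A Third Methoxy Group on a Weakly Cytotoxic Series

The source may hold more compounds than are shown below. What is called first, only, known or untested is meant among the compounds shown, and "the series" means these compounds.

Measured compounds:
Compound 1 `COc1ccc2[nH]cc(C(=O)/C(C#N)=C/C=C(\Cl)c3ccc(Br)cc3)c2c1`: > 100000 nM
Compound 2 `N#C/C(=C\C=C(/Cl)c1ccc(Br)cc1)C(=O)c1c[nH]c2ccccc12`: 81500 nM
Compound 3 `COc1ccc(/C(Cl)=C/C=C(\C#N)C(=O)c2c(C)[nH]c3ccccc23)cc1OC`: 93000 nM

All three were tested in a functional assay on MCF7 cells (Homo sapiens) for cytotoxicity, read by sulforhodamine B assay, with a stated time of 48 h; on this read-out lower numbers stand for stronger inhibition of growth and higher numbers for weaker inhibition of growth. Compound 2 gives 81500 nM. Compound 3 gives 93000 nM, which sits within the usual scatter of the value for compound 2, so the two cannot be told apart. For compound 1 the result is a limit of this assay rather than a number, > 100000 nM; the shared ceiling is the limit of > 100000 nM in this assay, at which 1 of the 3 values shown sits.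

Compound 1 arises from compound 2 by methoxy in place of hydrogen on an aromatic carbon. This step gave an at least 1.2-fold higher number from compound 2 to compound 1 (0.08 log units; that floor lies within the scatter).

Compound 4 `COc1cc(/C(Cl)=C/C=C(\C#N)C(=O)c2c(C)[nH]c3ccccc23)cc(OC)c1OC` has not yet been measured. It arises from compound 3 by methoxy in place of hydrogen on an aromatic carbon. How the core of compound 3 differs from that of compound 2 is not broken down here. The change to compound 4 is the same kind of change as that from compound 2 to compound 1, not the same: the earlier methoxy enters on a ring that is part of a fused or bridged system of two rings, meta to a fused ring and para to a fused ring, whereas the new one enters ortho to a methoxy group, meta to a large group and meta to a methoxy group.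

Resting on compound 3 at 93000 nM and on the small shift seen in an at least 1.2-fold higher number from compound 2 to compound 1 (0.08 log units; that floor lies within the scatter), the expected step is a 1.0-fold higher number from compound 3 to compound 4 (0.01 log units; within the scatter). Compound 4 is therefore estimated at 95000 nM, between 40000 nM and 200000 nM, with a fair chance that only a limit is reported.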

Compound 4, concentration for total growth inhibition: 83700 nM
The estimate for compound 4 lay 1.1-fold (0.05 log units) above the measured number; the measured number falls inside the stated range.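

In this assay, methoxy in place of hydrogen, entering ortho to a methoxy group and meta to a second one, gives a 1.1-fold lower number from compound 3 to compound 4 (0.05 log units; within the scatter), so this pair cannot be told apart. Set beside the earlier case, the same swap on a second core gives a small step each time, and the comparison reads: the same change on two cores in this assay, an at least 1.2-fold higher number (0.08 log units; that floor lies within the scatter) from compound 2 to compound 1 and a 1.1-fold lower number (0.05 log units; within the scatter) from compound 3 to compound 4; the limit leaves it open whether they differ. This shows that neither step can be told from the scatter, but it does not show that the change carries over from one core to the other in the same way, as the methoxy group enters at a different place on each core and the earlier step rests on a value at the ceiling of the assay: the limit of > 100000 nM in this assay, at which 1 of the 4 values shown sits.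

Still open, from the compounds shown here alone, is whether an amine or a carboxylic acid in place of the new methoxy group would move the number beyond the scatter in either direction. Also open, going by these compounds, is how large the step from hydrogen to methoxy really is on the core of compound 2, and whether a longer chain, such as ethoxy, on the same ring would behave as methoxy does.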